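This account rests on a few compounds, and the source may have more. Where it says the series, first, only, none or still open, it means among the compounds named here.

Measured compounds:
Compound 1, `COC(=O)/C=C\NC(=O)[C@H](O)C(C)(C)CO`: "not determined" (no result reported)
Compound 2, `CC(C)(C)OC(=O)/C=C/NC(=O)[C@@H](O)C(C)(C)CO`: -8%

In an ADME assay on HEK293 cells (Homo sapiens) for inhibition, read by CellTiter-Glo, with a stated time of 96 h, tested at 100 uM (a higher number here means more inhibition at the concentration tested (going by the name of the read-out), a lower number less inhibition), compound 1 has no single number, so it has no standing on this measure. For the measured compounds named here, compound 2 is the only compound with a result here; in this assay compound 2 gives -8%, which amounts to no inhibition at the concentration tested. Going by the values given here, no step between compound 1 and compound 2 is set out, so only their separate results can be stated.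

Compound 3, `CC(C)(CO)[C@@H](O)C(=O)N/C=C\C(=O)OCc1ccccc1`, has not yet been measured. It differs from compound 1 by phenyl in place of hydrogen on a saturated chain carbon bound to an oxygen next to a carbonyl group. The same difference, cut one bond further out, reads methyl to benzyl.

Among the compounds with values here, since compound 1 brings no number, the step from compound 1 to compound 3 has no starting point, and no step of any size in this assay can be expected in either direction beyond the scatter. Within the data shown here, the only anchor is compound 2, whose -8% shows no inhibition at the concentration tested. Compound 3 is expected to fall in the same region of the read-out. For compound 3 an inhibition of 0% is estimated, with a range from -15% to 18%.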

Compound 3, a percentage reported as inhibition, at one concentration (the size of the read-out at that concentration, not a potency): 7%
Compound 3: the middle estimate sits 7 percentage points below what was measured, within the range that was stated.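

No step can be read between compound 1 and compound 3, as compound 1 has no single number to set against compound 3. The compounds shown leave open whether methyl to benzyl changes the result in this assay at all. No supporting evidence bears on the result for compound 3.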